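Working notes: two measured compounds and one awaiting test

The source may report more compounds than this note shows. Statements on the series, on what has been measured and on what is new or still open speak of the compounds shown alone.

Measured so far:
- compound 1 `O=C1c2c(Br)c(Br)c(Br)c(Br)c2C(=O)N1Cc1ccccn1`: 35%
- compound 2 `O=C1c2c(Cl)c(Cl)c(Cl)c(Cl)c2C(=O)N1c1ccncc1`: 3%

In a functional assay on the whole organism with Rattus norvegicus as the target, read by spectrophotometry, with stated times of 14 days and 3 days, at a dose of 10 mg/kg by the oral route (a lower number here means less inhibition, a higher number more inhibition at the dose given (going by the name of the read-out)), compound 1 gives 35%, the higher of the two numbers. Compound 2 gives 3%, and the gap to compound 1 lies beyond the scatter. The two compounds differ in more than one place, both in the halogens on the shared core and in the group on the amide-type nitrogen, so no single-change step can be read from them.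

Compound 3 `O=C1c2c(Br)c(Br)c(Br)c(Br)c2C(=O)N1c1ncccn1` has not yet been measured. It differs from compound 1 as follows: pyrimidin-2-yl in place of (pyridin-2-yl)methyl on an amide-type nitrogen in a ring

Among the measured compounds shown here, no step of this kind is known. Compound 2, which also carries a six-membered aromatic ring directly on the amide-type nitrogen, shows the low value 3%, yet its halogens differ as well, so this is a weak guide. The step of a number 15 percentage points lower from compound 1 to compound 3 (beyond the scatter) is expected to be downward and of moderate size. For compound 3 the estimate is 20%, within the range 5% to 40%.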

Compound 3, a percentage reported as inhibition, in the whole organism at one dose (the size of the read-out at that dose, not a potency): 28%
Compound 3: middle estimate off by 8 percentage points, on the low side, within the range that was stated.
By their numbers in this assay, from the lowest: compound 2; then compounds 3 and 1 (each within the scatter of the next).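

Among the compounds shown here, this is the first single-change step: in this assay, pyrimidin-2-yl in place of (pyridin-2-yl)methyl on an amide-type nitrogen in a ring gives a number 7 percentage points lower from compound 1 to compound 3 (within the scatter) with the shared core held constant. A six-membered aromatic ring can therefore stand directly on this nitrogen, with no chain in between, and the number stays within the scatter of compound 1. Nothing measured here explains why these two groups read alike.

Open, on these data alone, is whether a group of another kind on this nitrogen, such as a morpholine amine or a carboxylic acid on a longer chain, would shift the number beyond the scatter. Also open, as far as these compounds go, is whether the same exchange would give a similar step on the chlorine-bearing core of compound 2.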